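The compounds below may be only part of what the source reports. "The series", "measured", "known", "first", "only" and "open" are said of these compounds alone.

Measured so far in an ADME assay on H9c2 cells (Rattus norvegicus) for cytotoxicity, read by resazurin assay, with a stated time of 72 h; on this read-out lower numbers stand for higher toxicity in this test and higher numbers for lower toxicity in this test:

compound 1 `C/C(=N\Nc1nc(C)cs1)c1ccc(Cl)c(Cl)c1`: 26100 nM
compound 2 `C/C(=N\Nc1nc(-c2ccccc2)cs1)c1ccc(Cl)c(Cl)c1`: > 50000 nM, which is a limit of this assay and not a number
compound 3 `C/C(=N\Nc1nc(-c2ccncc2)cs1)c1ccc(Cl)c(Cl)c1`: 41900 nM

Compound 3 holds the highest of the two numbers shown; its nearest neighbour is compound 1, and the gap a 1.6-fold higher number from compound 1 to compound 3 (0.21 log units; within the scatter) lies within the scatter. Compound 2 gives only a limit (the limit of > 50000 nM in this assay, at which 1 of the 3 values shown sits), so its position relative to compound 3 cannot be ordered beyond an at least 1.1-fold lower number from compound 2 to compound 3 (0.07 log units; that floor lies within the scatter).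

The next compound, compound 4 `C/C(=N\Nc1nc(-c2ccc(Cl)cc2Cl)cs1)c1ccc(Cl)c(Cl)c1`, differs from compound 3 in one place: 2,4-dichlorophenyl in place of pyridin-4-yl on an aromatic carbon.

Among the measured compounds shown here, the steps that bear on this change all concern the same aromatic carbon of the shared core. Replacing methyl gave an at least 1.9-fold higher number from compound 1 to compound 2 (0.28 log units; that floor lies within the scatter) and a 1.6-fold higher number from compound 1 to compound 3 (0.21 log units; within the scatter); exchanging one aryl ring for another gave an at least 1.1-fold lower number from compound 2 to compound 3 (0.07 log units; that floor lies within the scatter). None of these reaches beyond the scatter, so a step from compound 3 to compound 4 in this assay beyond the scatter is not expected in either direction; a small rise cannot be excluded given the limit of compound 2.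

Compound 4 is therefore expected at about 40000 nM, with a range from 15000 nM to 100000 nM, which amounts to an expected step of a 1.0-fold lower number from compound 3 to compound 4 (0.02 log units; within the scatter).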

Compound 4, half-maximal cytotoxic concentration: > 50000 nM
Compound 4 was reported as a limit; the forecaster's own chance of this, stated with the estimate: 35%; at least 1.2-fold (0.09 log units) between middle value and limit.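

In this assay compound 4 gives > 50000 nM, which is a limit of the assay and not a number. At the aromatic carbon next to the ring nitrogen, the exchange of pyridin-4-yl for 2,4-dichlorophenyl gives an at least 1.1-fold higher number from compound 3 to compound 4 (0.07 log units; that floor lies within the scatter), and the exchange of methyl for 2,4-dichlorophenyl gives an at least 1.9-fold higher number from compound 1 to compound 4 (0.28 log units; that floor lies within the scatter), so a ring bearing two chlorine atoms adds no readable step beyond the scatter, although these floors set no upper bound. The step between compound 2 and compound 4 cannot be read, because both compounds sit at the same assay limit, and the series now has two aryl groups that give no number here: the limit of > 50000 nM in this assay, at which 2 of the 4 values shown sit.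

With compound 2 and compound 4 both at this limit, the compounds shown do not settle whether the chlorine atoms on the phenyl ring change the read-out at all. Also open, as far as these compounds go, is how an amine, a carboxylic acid or a longer chain on this aromatic carbon would compare with the methyl group of compound 1 at 26100 nM.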